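Cytotoxicity notes: longer alkylsulfanyl chain on the shared core

This account rests on a few compounds, and the source may have more. Where it says the series, first, only, none or still open, it means among the compounds named here.

Measured compounds:
- Compound 1 `CC(C)CSc1nc(N)nc2c1ncn2/C=C1/CC1(CO)CO`: in an ADME assay on BCBL1 cells (Homo sapiens) for cytotoxicity, with a stated time of 7 days (on this read-out higher numbers stand for lower toxicity in this test and lower numbers for higher toxicity in this test), compound 1 gives > 20000 nM, which is a limit of the assay and not a number.
- Compound 2 `COCCOc1nc(N)nc2c1ncn2/C=C1/CC1(CO)CO`: in this assay compound 2 gives > 20000 nM, again a limit and not a number.
- Compound 3 `Nc1nc(NC2CCCCC2)c2ncn(/C=C3/CC3(CO)CO)c2n1`: in this assay compound 3 gives > 20000 nM, also a limit and not a number.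

Within the data shown here, compound 1 therefore stands at the upper edge of what this assay reports; all three values sit at the same limit (the limit of > 20000 nM in this assay, at which 3 of the 3 values shown sit), so no compound can be placed above or below another.

The measured steps are a step that the two limits leave unreadable from compound 1 to compound 2 and a step that the two limits leave unreadable from compound 1 to compound 3; both start from compound 1, and neither size can be read, as both ends are limits. The step between compound 2 and compound 3 is a step that the two limits leave unreadable from compound 2 to compound 3, equally unreadable.

Compound 4 `CCCCCCSc1nc(N)nc2c1ncn2/C=C1/CC1(CO)CO` differs from compound 1 by pentyl in place of isopropyl on a saturated chain carbon bound to a sulfur. Among the measured compounds shown here, no measured step varies the chain on the sulfur, so none of the three bears directly on this change, and the measured steps that do exist give no readable size in this assay at all.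

With every value at the limit, the expectation for compound 4 in this assay is an estimate of 22000 nM, with a range from 8000 nM to 60000 nM. The estimated step that the limit leaves unreadable from compound 1 to compound 4 is expected to lie within the scatter, and most likely only a limit will be reported again.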

Compound 4, half-maximal cytotoxic concentration: > 20000 nM
Compound 4 ended at the assay's limit; the forecaster's own chance of this, stated with the estimate: 75%; the middle value does not contradict the limit.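

In this assay compound 4 gives > 20000 nM as a limit and not a number. Its steps from compound 1, compound 2 and compound 3 cannot be read, so no new step results, with every value at the same edge: the limit of > 20000 nM in this assay, at which 4 of the 4 values shown sit.

Going by these compounds, whether this assay separates hexylsulfanyl from isobutylsulfanyl on the shared core at all stays open.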